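Two limits and an untested fluorophenyl analogue

The source may hold more compounds than are shown below. What is called first, only, known or untested is meant among the compounds shown, and "the series" means these compounds.

Compound 1 `CCCc1ccc(-c2cc(=O)c3c(o2)C(CC)(CC)C(=O)C(CC)=C3O)cc1`: > 53 uM (a limit)
Compound 2 `CCC1=C(O)c2c(oc(-c3ccc(CBr)cc3)cc2=O)C(CC)(CC)C1=O`: > 46.5 uM (a limit)

In a functional assay on KB cells (Homo sapiens) for antiproliferative activity, read by sulforhodamine B assay, with a stated time of 3 days (a higher number here means that more compound is needed for the effect, a lower number that less compound is needed), compound 2 gives no number, only the limit > 46.5 uM. Compound 1 likewise gives only a limit, > 53 uM. Neither compound can therefore be ranked against the other, and compound 2 has no exact place on the scale.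

Compound 3 `CCC1=C(O)c2c(oc(-c3cccc(F)c3)cc2=O)C(CC)(CC)C1=O` is still to be measured. It carries 3-fluorophenyl in place of 4-(bromomethyl)phenyl on an aromatic carbon, next to the ring oxygen (3-fluorophenyl in place of 4-(bromomethyl)phenyl on an aromatic carbon). For the measured compounds named here, only one measured step bears on this change: a step that the two limits leave unreadable from compound 1 to compound 2. That step, bromo in place of ethyl on a saturated chain carbon bound to an aromatic carbon, alters the same aryl substituent but gives no size to carry over. With no readable step to build on, no change beyond the scatter is expected in this assay, in either direction, and another limit is the most likely report. The estimated step is an at least 1.0-fold lower number from compound 2 to compound 3 (0.01 log units; that floor lies within the scatter). For compound 3 the expected value is 45 uM, with an estimated range from 15 uM to 70 uM.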

Compound 3, concentration for half-maximal effect: > 56.2 uM
Compound 3: no number, only a limit; the forecaster's own chance of this, stated with the estimate: 70%; middle value at least 1.2-fold (0.09 log units) away from the limit.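

In this assay compound 3 gives only a limit, > 56.2 uM. Compound 1 and compound 2 also give only limits, so no step can be read among the three compounds. The compounds shown leave open whether 4-propylphenyl, 4-(bromomethyl)phenyl or 3-fluorophenyl on the shared core differ at all in this assay.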